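The compounds below may be only part of what the source reports. "The series", "measured", "known", "first", "only" and "open" are said of these compounds alone.

Measured in an ADME assay on BHK-21 cells (Mesocricetus auratus) for cytotoxicity, with a stated time of 3 days; on this read-out higher numbers stand for lower toxicity in this test and lower numbers for higher toxicity in this test:
- compound 1 `O=C(CCSc1nnc(-c2ccncc2)s1)Nc1ccc(Cl)cc1Cl`: > 50000 nM, a limit of the assay
- compound 2 `O=C(CCSc1nnc(-c2ccncc2)s1)Nc1ccccc1Cl`: > 50000 nM, a limit of the assay
- compound 3 `CC(CSc1nnc(-c2ccncc2)s1)C(=O)NCc1ccccc1`: > 50000 nM, a limit of the assay

Compound 3 stands only at a limit in this assay; all three values shown sit at the limit of > 50000 nM in this assay, at which 3 of the 3 values shown sit. Within the data shown here, the one step between measured compounds, a step that the two limits leave unreadable from compound 1 to compound 2, lies between two limits and its size cannot be read. Compound 4 `O=C(CCSc1nnc(-c2ccncc2)s1)NCc1ccccc1` differs from compound 3 by hydrogen in place of methyl on a saturated chain carbon bound to a carbonyl carbon and a saturated chain carbon. No measured step bears on this change, and nothing shown gives a direction for it. Compound 4 is expected to stay at the limit, with a step that the limit leaves unreadable from compound 3 to compound 4 estimated as none beyond the scatter. The estimate for compound 4 in this assay is 100000 nM, range 30000 nM to 300000 nM.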

Compound 4, half-maximal cytotoxic concentration: 18700 nM
Compound 4: middle estimate off by 5.3-fold (0.73 log units), on the high side; measured number below the stated range.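

In this assay, hydrogen in place of methyl on a saturated chain carbon bound to a carbonyl carbon and a saturated chain carbon gives an at least 2.6-fold lower number from compound 3 to compound 4 (0.42 log units; beyond the scatter), so this position can move the read-out towards higher toxicity in this test. Benzyl in place of 2-chlorophenyl on an amide-type nitrogen gives an at least 2.6-fold lower number from compound 2 to compound 4 (0.42 log units; beyond the scatter), and benzyl in place of 2,4-dichlorophenyl there gives an at least 2.6-fold lower number from compound 1 to compound 4 (0.42 log units; beyond the scatter). Compound 4 is the only compound shown with a number rather than a limit: the limit of > 50000 nM in this assay, at which 3 of the 4 values shown sit.

On these data alone, the full size of each step stays open, since compound 1, compound 2 and compound 3 stand at a limit. Also open, as far as these compounds go, is whether an ethyl or hydroxyl group on that chain carbon gives a number like that of compound 4 or a limit like that of compound 3.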